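A few compounds are considered here, and "the series" means these few. Any claim that something is new, unique, unknown or untested is made for them only; others in the source may bear on it.

Of the compounds shown here, two built on a shared core have been tested in an assay on isolated protein for inhibition of histone deacetylase 4 (Homo sapiens), with a stated time of 1 h; on this read-out higher numbers stand for weaker inhibition and lower numbers for stronger inhibition. Compound 2 `O=C(COc1ccc2cc(/C=C3/SC(=O)NC3=O)ccc2c1)Nc1ccc([N+](=O)[O-])cc1` gives 1700 nM, the lower of the two numbers. Compound 1 `CCOc1ccc2nc(NC(=O)COc3ccc4cc(/C=C5/SC(=O)NC5=O)ccc4c3)sc2c1` gives 3600 nM in this assay, a higher number that lies beyond the usual scatter. Compound 3 `Cc1cc(NC(=O)COc2ccc3cc(/C=C4/SC(=O)NC4=O)ccc3c2)no1` is the next step: 5-methyl-1,2-oxazol-3-yl in place of 4-nitrophenyl on an amide-type nitrogen. For the measured compounds named here, with no measured step of this kind to lean on, the move from compound 2 to compound 3 is expected to be modest, most likely a small shift toward a higher number, and possibly none beyond the scatter. For compound 3 the estimate in this assay is 2500 nM, with a range from 900 nM to 7000 nM, an expected step of a 1.5-fold higher number from compound 2 to compound 3 (0.17 log units; within the scatter).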

Compound 3, half-maximal inhibitory concentration: 1700 nM
Estimate against measurement, compound 3: 1.5-fold (0.17 log units) above, and the stated range covers the measured number.
By their numbers in this assay, from the lowest: compounds 2 and 3 (each within the scatter of the next); then compound 1.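

In this assay, 5-methyl-1,2-oxazol-3-yl in place of 4-nitrophenyl on the amide-type nitrogen gives no change at the digits printed from compound 2 to compound 3 (within the scatter) as its result. At this position, then, a five-membered aromatic ring with 2 hetero atoms and 6 heavy atoms reads the same as a six-membered carbon ring carrying a nitro group, with 9 heavy atoms. The data offer no measured explanation for this match. Still open, on these data alone, is how an unsubstituted phenyl ring, a carboxylic acid or a longer alkyl chain would read on this nitrogen.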